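The source may report more compounds than this note shows. Statements on the series, on what has been measured and on what is new or still open speak of the compounds shown alone.

Working notes on the series. In a functional assay on A549 cells (Homo sapiens) for antiproliferative activity, read by MTT assay, with a stated time of 72 h (a lower number here means a stronger inhibitor, a higher number a weaker inhibitor), compound 1 (`CC/C=C/C(=O)Nc1cccc(Oc2nc(Nc3ccn(C)n3)nc3c2CSCC3)c1`) gives 36800 nM, compound 2 (`CC(C)=CC(=O)Nc1cccc(Oc2nc(Nc3ccn(C)n3)nc3c2CSCC3)c1`) gives 44200 nM and compound 3 (`CC(C)/C=C/C(=O)Nc1cccc(Oc2nc(Nc3ccn(C)n3)nc3c2CSCC3)c1`) gives 33500 nM. Compound 1 stands within the scatter of both other compounds, so no order among the three can be read: the steps are a 1.2-fold higher number from compound 1 to compound 2 (0.08 log units; within the scatter), a 1.1-fold lower number from compound 1 to compound 3 (0.04 log units; within the scatter) and a 1.3-fold lower number from compound 2 to compound 3 (0.12 log units; within the scatter).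

The next compound to be measured is compound 4 (`CC/C=C/C(=O)Nc1cccc(Oc2nc(Nc3ccc(OC)cc3)nc3c2CSCC3)c1`). Its change from compound 1 is 4-methoxyphenyl in place of 1-methyl-1H-pyrazol-3-yl on a nitrogen on an aromatic ring. The group on the carbonyl carbon stays as in compound 1.

All three measured steps alter the group on the carbonyl carbon, so none bears directly on this change. Among the compounds with values here, no measured compound varies the group on that nitrogen, and the data give no size or direction for such a change. With nothing pointing either way, no shift beyond the scatter is expected in this assay, though the uncertainty is wide. The expected step is a 1.2-fold lower number from compound 1 to compound 4 (0.09 log units; within the scatter). Compound 4 is estimated at 30000 nM, with an expected range from 10000 nM to 70000 nM.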

Compound 4, half-maximal inhibitory concentration: 20100 nM
Compound 4: middle estimate off by 1.5-fold (0.17 log units), on the high side; low and high end bracket the measured number.
By their numbers in this assay, from the lowest: compounds 4, 3, 1 and 2 (each within the scatter of the next, the first and the last beyond it).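

Within the data shown here, the first change to the group on this nitrogen on an aromatic ring, from (1-methyl-1H-pyrazol-3-yl)amino to (4-methoxyphenyl)amino, gives in this assay a 1.8-fold lower number from compound 1 to compound 4 (0.26 log units; within the scatter). Among these compounds, a one-ring swap of this kind, from a five-membered aromatic ring with 2 hetero atoms to a six-membered aromatic ring of carbon only, therefore produces no change that can be read at this position, which the earlier compounds could not show because they vary only the group on the carbonyl carbon. No supporting measurement bears on this result, so nothing can be said about what lies behind it.

The compounds shown leave open whether a different kind of group on this nitrogen, such as a phenyl carrying a piperazine or a plain ethyl chain, would move the number beyond the scatter. Also open is whether 4-methoxyphenyl behaves the same way when paired with 3-methylbut-1-en-1-yl or 2-methylprop-1-en-1-yl on the carbonyl carbon, since it is shown here with but-1-en-1-yl alone.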